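The compounds below may be only part of what the source reports. "The series", "measured", "known", "first", "only" and "open" are said of these compounds alone.

Of the three compounds with a measured number, compound 2 `COc1cc(C2=NN(C(C)=O)C(c3c(Cl)cccc3Cl)O2)cc(OC)c1OC` stands at the bottom: in a functional assay on PC-3 cells (Homo sapiens) for antiproliferative activity, read by MTT assay, tested at 5 uM (on this read-out higher numbers stand for a stronger effect at the one concentration tested and lower numbers for a weaker effect), compound 2 gives -2.2%. The nearest of the other two is compound 1 `COc1cc(C(=O)N/N=C/c2ccc(F)c(F)c2)cc(OC)c1OC`, which in this assay gives 43.7%, a reading higher than that of compound 2 by more than the usual scatter. The furthest is compound 3 `COc1cc(C(=O)N/N=C/c2ccc(C(F)(F)F)cc2)cc(OC)c1OC`, which in this assay gives 61.6%, again higher than compound 2 by more than the scatter. For the measured compounds named here, compounds 1 and 3 share the open acylhydrazone core, whereas compound 2 carries the cyclised, acetylated five-membered ring, so no measured pair differs in a single place and no step can be read directly.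

Compound 4 `COc1cc(C2=NN(C(C)=O)C(c3ccc(C(F)(F)F)cc3)O2)cc(OC)c1OC` keeps the core of compound 2 and differs from it only in the aryl group: 4-(trifluoromethyl)phenyl in place of 2,6-dichlorophenyl on a saturated ring carbon. The group entering is the one that, on the open core, belongs to compound 3 with its 61.6%. Going by the values given here, with no single-change step to lean on, an upward move is expected from compound 2 to compound 4 in this assay, of modest size and probably not far beyond the scatter, a number 14.2 percentage points higher from compound 2 to compound 4 (beyond the scatter). Compound 4 is therefore expected to give 12% in this assay, within a range from -8% to 40%.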

Compound 4, a percentage reported as inhibition, at one concentration (the size of the read-out at that concentration, not a potency): -0.7%
Compound 4: the middle estimate sits 12.7 percentage points above what was measured; the measured number falls inside the stated range.
By their numbers in this assay, from the lowest: compounds 2 and 4 (each within the scatter of the next); then compound 1; then compound 3.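

In this assay, for the compounds shown here, putting 4-(trifluoromethyl)phenyl in place of 2,6-dichlorophenyl on the saturated ring carbon gives a number 1.5 percentage points higher from compound 2 to compound 4 (within the scatter), the first step that can be read directly. On the core of compound 2, this position therefore tolerates an exchange of one substituted phenyl group for another, larger by the counted atoms and carrying different halogens, without any change in the reading that stands beyond the usual spread of repeats. Nothing measured here offers an explanation for why these two aryl groups read alike.

The compounds shown leave open whether a group of another kind on that saturated ring carbon, such as a pyridine ring, a dimethylamino-bearing phenyl, a carboxylic acid or a plain alkyl chain, would move the number on this core, and whether 2,6-dichlorophenyl on the open acylhydrazone core would read as 4-(trifluoromethyl)phenyl does there. They also leave open what happens when the acetyl group on the ring is replaced by a propionyl group or by a bare hydrogen, since every cyclised compound shown carries that same acetyl.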